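Chloro to Methyl Swap on a Thiazol-2-ylidene Hydrazide Series

This account rests on a few compounds, and the source may have more. Where it says the series, first, only, none or still open, it means among the compounds named here.

Measured compounds:
compound 1 `Cc1ccc(-c2cs/c(=N/NC(=O)CSc3nnnn3-c3ccccc3)n2-c2ccccc2)cc1`, 66.8%
compound 2 `O=C(CSc1nnnn1-c1ccccc1)N/N=c1/scc(-c2ccc(Cl)cc2)n1-c1ccccc1`, 77.4%
compound 3 `O=C(CSc1ncccn1)N/N=c1/scc(-c2ccc(Cl)cc2)n1-c1ccccc1`, 95.9%

Three compounds were tested in a functional assay on C6 cells (Rattus norvegicus) for cytotoxicity, read by MTT assay, with a stated time of 24 h, tested at 6 ug/mL; a higher number here means a weaker effect of the compound at the concentration tested, a lower number a stronger effect. Compound 3 stands highest, with compound 2 and then compound 1 lower. The step of a number 18.5 percentage points higher from compound 2 to compound 3 (beyond the scatter) arises from the core change (pyrimidin-2-yl in place of 1-phenyl-1H-tetrazol-5-yl on a sulfur). Within the data shown here, the step of a number 10.6 percentage points lower from compound 2 to compound 1 (beyond the scatter) rests on (methyl in place of chloro on an aromatic carbon), the only change between compound 2 and compound 1.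

Compound 4 `Cc1ccc(-c2cs/c(=N/NC(=O)CSc3ncccn3)n2-c2ccccc2)cc1` has not yet been measured. It differs from compound 3 by methyl in place of chloro on an aromatic carbon, the same change as from compound 2 to compound 1, on the same place, against the core of compound 3. Since that change gave a number 10.6 percentage points lower from compound 2 to compound 1 (beyond the scatter), a step of similar size is expected here, a number 10.9 percentage points lower from compound 3 to compound 4 (beyond the scatter). Compound 4 is therefore estimated at 85%, between 72% and 98%.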

Compound 4, a percentage reported as activity, at one concentration (the size of the read-out at that concentration, not a potency): 93.2%
For compound 4 the middle estimate is 8.2 percentage points below the measured one; the range from low to high includes it.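

In this assay, methyl in place of chloro on an aromatic carbon gives a number 2.7 percentage points lower from compound 3 to compound 4 (within the scatter), and the change carries from one core to the other without a difference that can be told apart from the scatter: the same change on two cores in this assay, a number 10.6 percentage points lower (beyond the scatter) from compound 2 to compound 1 and a number 2.7 percentage points lower (within the scatter) from compound 3 to compound 4, 7.9 percentage points apart, within the scatter of two such steps Pyrimidin-2-yl in place of 1-phenyl-1H-tetrazol-5-yl on a sulfur gives a number 26.4 percentage points higher from compound 1 to compound 4 (beyond the scatter), and this change also carries across the two cores: the same change on two cores in this assay, a number 18.5 percentage points higher (beyond the scatter) from compound 2 to compound 3 and a number 26.4 percentage points higher (beyond the scatter) from compound 1 to compound 4, 7.9 percentage points apart, within the scatter of two such steps This rests on two pairs of compounds only, so it does not show that either change would keep its size on any other core, nor that methyl in place of chloro has a real effect on the core of compound 3.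

The compounds shown leave open how a methoxy group or a fluorine in place of the chloro would read in this assay. They also leave open how an amine or a carboxylic acid in place of the pyrimidin-2-yl on the sulfur would read.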